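This account rests on a few compounds, and the source may have more. Where it says the series, first, only, none or still open, it means among the compounds named here.

In an ADME assay on HEK293 cells (Homo sapiens) for cytotoxicity, read by CellTiter-Glo, with a stated time of 72 h (on this read-out lower numbers stand for an effect already at smaller amounts and higher numbers for an effect only at larger amounts of compound), three compounds have been measured so far. Compound 1 (`CC1=C2CC(C)(C)[C@@H](C)CC(=O)/C(C)=C\C3=C[C@H](C)C[C@]3(O2)C1=O`) gives 26000 nM, compound 2 (`CC1=C2CC(C)(C)/C=C/[C@H](O)/C(C)=C\C3=C[C@H](C)C[C@]3(O2)C1=O`) gives 26000 nM, and compound 3 (`CC(=O)O[C@H]1/C=C/C(C)(C)CC2=C(C)C(=O)[C@]3(C[C@@H](C)C=C3/C=C\1C)O2`) gives 26000 nM. Compound 3 therefore stands level with the other two, and the numbers separate none of the three.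

Compound 4 (`CC(=O)O[C@@H]1/C=C/C(C)(C)CC2=C(C)C(=O)[C@]3(C[C@@H](C)C=C3/C=C\1C)O2`) is related to compound 3 by a single difference: the two compounds have the same atoms and bonds and differ only in configuration as drawn: 1 of 5 stereo elements differ; a stereocentre at a saturated ring carbon is drawn S in compound 3 and R in compound 4. No atom leaves or enters, so only the drawn configuration at that saturated ring carbon distinguishes the pair.

Going by the values given here, only one measured step offers any guidance, and it concerns a different kind of change. Placing acetyl in place of hydrogen on an oxygen on a saturated carbon gave no change at the digits printed from compound 2 to compound 3 (within the scatter). Among the compounds with values here, no measured pair differs in configuration alone, so the data do not show directly what such a change does here, and a surprise remains possible.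

With compound 3 at 26000 nM and the step of no change at the digits printed from compound 2 to compound 3 (within the scatter) as the nearest evidence, no shift beyond the scatter is expected, and neither direction is favoured. The expected outcome is no change at the digits printed from compound 3 to compound 4 (within the scatter). In this assay, the estimated value for compound 4 is 26000 nM, within an expected range of 14000 nM to 40000 nM.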

Compound 4, half-maximal effective concentration: 26000 nM
Estimate against measurement, compound 4: no gap at the digits printed; the range from low to high includes it.
By their numbers in this assay, from the lowest: compounds 1, 2, 3 and 4 (each within the scatter of the next).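

In this assay, redrawing a stereocentre at a saturated ring carbon from S to R gives no change at the digits printed from compound 3 to compound 4 (within the scatter). Going by these compounds alone, until now the only measured step was a change of group, so the data said nothing about the spatial arrangement at this carbon; this pair shows that, with the acetyl compounds, the read-out does not separate the two drawn configurations, and the result holds for this one stereocentre alone. The comparison is an unusually clean one, since no atom enters or leaves and a single feature separates the pair: the fact that compounds 3 and 4 differ only in the configuration as drawn

As far as these compounds go, whether the same redrawing would also leave the value in place in a compound with hydrogen in place of acetyl on that oxygen remains open, and so does the effect of changing any of the other four stereo elements. Also open, from the compounds shown here alone, is whether a different group on that oxygen, such as a longer chain like hexanoyl, or a group carrying an amine or a carboxylic acid, would move the value at all or make the two configurations differ.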